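This account rests on a few compounds, and the source may have more. Where it says the series, first, only, none or still open, it means among the compounds named here.

Working notes on the series in an ADME assay on MRC5 cells (Homo sapiens), read by MTT assay, with a stated time of 72 h; on this read-out lower numbers stand for stronger inhibition and higher numbers for weaker inhibition.

Compound 3, `COc1ncnc2c1c(-c1ccoc1)cn2[C@@H]1O[C@H](CO)[C@@H](O)[C@H]1O`, gives 29400 nM. Compound 1, `C#Cc1cn([C@@H]2O[C@H](CO)[C@@H](O)[C@H]2O)c2ncnc(N(C)C)c12`, gives 36100 nM, and the two numbers sit within the scatter of each other, so compound 3 stands alongside compound 1 rather than apart from it. Compound 2, `CNc1ncnc2c1c(-c1ccoc1)cn2[C@@H]1O[C@H](CO)[C@@H](O)[C@H]1O`, gives only a limit of the assay, > 100000 nM. Among the measured compounds shown here, the one measured step, an at least 3.4-fold lower number from compound 2 to compound 3 (0.53 log units; beyond the scatter), rests on the limit of > 100000 nM in this assay, at which 1 of the 3 values shown sits, and is therefore a floor rather than a number.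

The next compound is compound 4, `CN(C)c1ncnc2c1c(-c1ccoc1)cn2[C@@H]1O[C@H](CO)[C@@H](O)[C@H]1O`. The change from compound 3 to compound 4 is dimethylamino in place of methoxy on an aromatic carbon. For the measured compounds named here, no measured step covers this exchange directly. The step from compound 2 to compound 3 concerns methylamino and methoxy, not dimethylamino, so it bears only loosely. Compound 1 carries dimethylamino and gives 36100 nM, within the scatter of compound 3, which points to no step beyond the scatter. Compound 4 is therefore expected to give 35000 nM, within 15000 nM to 80000 nM, an expected step of a 1.2-fold higher number from compound 3 to compound 4 (0.08 log units; within the scatter).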

Compound 4, half-maximal inhibitory concentration: > 100000 nM
Compound 4 gave a limit, no number (the forecaster's own chance of this, stated with the estimate: 20%); middle value at least 2.8-fold (0.45 log units) from the limit.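

With furan-3-yl held fixed in this assay, dimethylamino in place of methoxy on this aromatic carbon gives an at least 3.4-fold higher number from compound 3 to compound 4 (0.53 log units; beyond the scatter), so methoxy is here set apart from both nitrogen-linked groups shown on this core. With dimethylamino held fixed, furan-3-yl in place of ethynyl gives an at least 2.7-fold higher number from compound 1 to compound 4 (0.44 log units; beyond the scatter), so dimethylamino does not give the same result on both cores, and the number of compound 1 does not carry over to compound 4. Compound 2 and compound 4 each give a limit, so the step between them cannot be read, and the steps to compound 4 give only a minimum size: the limit of > 100000 nM in this assay, at which 2 of the 4 values shown sit.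

On these data alone, whether ethoxy or an unsubstituted amino group on this aromatic carbon would stay with methoxy or join methylamino and dimethylamino remains open. Also open, as far as these compounds go, is how furan-3-yl and ethynyl compare with methoxy kept fixed.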